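This account rests on a few compounds, and the source may have more. Where it says the series, first, only, none or still open, it means among the compounds named here.

Measured so far in a functional assay on HeLa cells (Homo sapiens) for inhibition, read by MTT assay, with a stated time of 4 days; on this read-out lower numbers stand for stronger inhibition and higher numbers for weaker inhibition:
compound 1 `COc1cc(NC(C)CCCNC(=O)NNC(=O)N(CCO)CCO)c2ncccc2c1` gives only a limit of the assay, > 250000 nM.
compound 2 `O=C(NC(c1ccccc1)c1ccc(Cl)cc1)n1nnc2ccccc21` gives 87000 nM.
compound 3 `COc1cc(NC(C)CCCNC(=O)NNC(=O)Nc2ccc(Cl)c(C(F)(F)F)c2)c2ncccc2c1` gives 17000 nM.

Compound 3 holds the lowest of the two numbers; compound 2 lies above it by a gap beyond the scatter. Compound 1 contributes a limit, not a number (the limit of > 250000 nM in this assay, at which 1 of the 3 values shown sits).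

Compound 4 `COc1cc(NC(C)CCCNC(=O)NNC(=O)NCCCO)c2ncccc2c1` differs from compound 3 by 3-hydroxypropyl in place of 4-chloro-3-(trifluoromethyl)phenyl on an amide-type nitrogen. Going by the values given here, the one measured step that bears on this is an at least 14-fold lower number from compound 1 to compound 3 (1.16 log units; beyond the scatter), where the aryl group replaced bis(2-hydroxyethyl)amino on the carbonyl carbon. The change toward compound 4 runs the other way, to a hydroxy-bearing chain, so a large step to a higher number is expected, an 8.8-fold higher number from compound 3 to compound 4 (0.95 log units; beyond the scatter). Compound 4 is estimated at 150000 nM, within 40000 nM to 400000 nM, with a real chance that only a limit is reported, as for compound 1 (the limit of > 250000 nM in this assay, at which 1 of the 3 values shown sits).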

Compound 4, half-maximal inhibitory concentration: > 250000 nM
Compound 4: a limit, no number; the forecaster's own chance of this, stated with the estimate: 45%; middle value at least 1.6-fold (0.22 log units) away from the limit.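

In this assay, the step at this amide-type nitrogen is now seen directly: 3-hydroxypropyl in place of 4-chloro-3-(trifluoromethyl)phenyl gives an at least 14-fold higher number from compound 3 to compound 4 (1.16 log units; beyond the scatter). Compound 1 and compound 4 both end at a limit of the assay, so the step between them cannot be read: the limit of > 250000 nM in this assay, at which 2 of the 4 values shown sit. Among the compounds sharing this core, only compound 3 gives a number.

The compounds shown leave open whether the step follows the ring itself, the chlorine or the trifluoromethyl group. A plain phenyl or a cyclohexyl group at this nitrogen would bear on that question.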